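Aryl substituent changes in a thiosemicarbazone series

The source may report more compounds than this note shows. Statements on the series, on what has been measured and on what is new or still open speak of the compounds shown alone.

Measured so far:
compound 1 `CC1=CC[C@H](C(C)(C)NC(=S)N/N=C/c2ccccc2Cl)CC1` in a functional assay on PC-3 cells (Homo sapiens) for inhibition, read by sulforhodamine B assay, with a stated time of 48 h; on this read-out lower numbers stand for stronger inhibition of growth and higher numbers for weaker inhibition of growth: 50 nM
compound 2 `CC1=CC[C@H](C(C)(C)NC(=S)N/N=C/c2cccc(Cl)c2)CC1` in this assay : 600 nM
compound 3 `CC1=CC[C@H](C(C)(C)NC(=S)N/N=C/c2ccccc2[N+](=O)[O-])CC1` in this assay : 1700 nM

Compound 1 and compound 2 hold the same atoms joined differently; the core difference is 3-chlorophenyl in place of 2-chlorophenyl on a carbon with a double bond to nitrogen. That rearrangement alone gives a 12-fold higher number from compound 1 to compound 2 (1.08 log units; beyond the scatter). Compound 3 arises from compound 1 by nitro in place of chloro on an aromatic carbon, a step of a 34-fold higher number from compound 1 to compound 3 (1.53 log units; beyond the scatter). Compound 2 and compound 3 differ in more than one place; their values only show compound 3 with the higher number.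

Compound 4 `CC1=CC[C@H](C(C)(C)NC(=S)N/N=C/c2cccc([N+](=O)[O-])c2)CC1` is not yet measured. It stands to compound 2 as compound 3 stands to compound 1: nitro in place of chloro on an aromatic carbon. This is the same kind of change, not the same: from compound 1 to compound 3 the place is ortho to a large group, from compound 2 to compound 4 it is meta to a large group.

Among the compounds with values here, a step of a 13-fold higher number from compound 2 to compound 4 (1.12 log units; beyond the scatter) is expected for compound 4 in this assay, because the one comparable step a 34-fold higher number from compound 1 to compound 3 (1.53 log units; beyond the scatter) was large, though the place is not identical. Compound 4 is estimated at 8000 nM, plausibly between 2000 nM and 40000 nM.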

Compound 4, concentration for 50% growth inhibition: 9500 nM
For compound 4 the middle estimate is 1.2-fold (0.07 log units) below the measured one, within the range that was stated.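

On the core of compound 2, nitro in place of chloro gives a 16-fold higher number from compound 2 to compound 4 (1.20 log units; beyond the scatter) in this assay, so this change again goes with weaker inhibition of growth. Set beside the step on the core of compound 1, the size of the change carries over between the two cores without a difference that can be told apart: the same change on two cores in this assay, a 34-fold higher number (1.53 log units; beyond the scatter) from compound 1 to compound 3 and a 16-fold higher number (1.20 log units; beyond the scatter) from compound 2 to compound 4, 2.1-fold (0.33 log units) apart, within the scatter of two such steps. These are only two cases on closely related cores, so they do not show that the step would hold on a core changed elsewhere or at any other place on the aromatic ring, and they give no reason for its size.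

The compounds shown leave open whether other groups in place of chloro, such as an amine, a methoxy group or a carboxylic acid, would also give a higher number than chloro. From the compounds shown here alone, it also remains open whether replacing the dimethyl-substituted carbon linking the thiourea nitrogen to the cyclohexene part with a longer chain would change the size of the nitro step.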